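A few compounds are considered here, and "the series" means these few. Any claim that something is new, unique, unknown or untested is made for them only; others in the source may bear on it.

In an ADME assay on liver (Homo sapiens) for metabolic stability, read by LC-MS, using microsomes and NADPH (a lower number here means that less of the compound is left, a higher number that more of the compound is left), compound 1 `CCCN(Cc1ccc(OCCN2C(=O)CCC2=O)c(C)c1)C(CC(=O)O)c1ccc(Cl)cc1` gives 85%. Compound 2 `CCCN(Cc1ccc(OCCN2C(=O)CCC2=O)c(C)c1)[C@H](CC(=O)O)c1ccc(Cl)cc1` gives 100%, and compound 3 `Cc1cc(CN(CCC(F)(F)F)C(CC(=O)O)c2ccc(Cl)cc2)ccc1OCCN1C(=O)CCC1=O` gives 81%. Compound 1 therefore lies within the scatter of compound 3 and clearly under compound 2.

The next compound, compound 4 `CCCN(Cc1ccc(OCCn2c(=O)ccn(C)c2=O)c(C)c1)C(CC(=O)O)c1ccc(Cl)cc1`, differs from compound 1 at one end of the molecule: a group of 9 heavy atoms (5 carbon, 2 nitrogen, 2 oxygen; one six-membered aromatic ring with 2 hetero atoms) in place of a group of 7 heavy atoms (4 carbon, 1 nitrogen, 2 oxygen; one five-membered non-aromatic ring with 1 hetero atom), on a saturated chain carbon, two bonds along the chain from an oxygen on an aromatic ring. Two measured steps offer context, though neither touches this end group. The first is a number 15 percentage points higher from compound 1 to compound 2 (beyond the scatter), and the only difference behind it is the fact that one of compounds 1 and 2 is drawn with a defined configuration and the other without, at the place where they differ. The second exchanges trifluoromethyl for methyl on a saturated chain carbon, two bonds along the chain from an amine nitrogen, and amounts to a number 4 percentage points lower from compound 1 to compound 3 (within the scatter). Neither step shows what replacing the 2,5-dioxopyrrolidin-1-yl group does, so they offer only a loose guide: single changes in this small set have moved the number modestly or not beyond the scatter.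

Compound 1 already stands at 85%, which leaves more room for a fall than for a rise in this assay. The expected change is a number 5 percentage points lower from compound 1 to compound 4 (within the scatter), an estimated step within the scatter. For compound 4 the expected value is 80%, with an estimated range from 60% to 97%.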

Compound 4, percent of the compound remaining: 30%
Beside the measured number, compound 4's estimate is 50 percentage points above it, outside the stated range (below it).
By their numbers in this assay, from the lowest: compound 4; then compounds 3 and 1 (each within the scatter of the next); then compound 2.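

In this assay, among the compounds shown here, this is the first single change in the set to produce a large step: putting the six-membered aromatic ring with 2 hetero atoms in place of 2,5-dioxopyrrolidin-1-yl gives a number 55 percentage points lower from compound 1 to compound 4 (beyond the scatter). The earlier changes, one at a stereocentre and one on the chain at the amine nitrogen, moved the number only modestly or not beyond the scatter, whereas the group on the saturated chain carbon, two bonds along the chain from an oxygen on an aromatic ring, proves to be a place where one exchange alone can use up most of the compound's standing in this assay. The compounds shown offer no measured property that accounts for this fall.

Ring size, aromatic character and the number of hetero atoms all change together in this one step, which leaves open which of them carries the loss. On these data alone, a piperidine-2,6-dione or an open-chain amide at the same place could pull these apart, and it also remains open whether a defined configuration, as drawn in compound 2, would alter the number for the group in compound 4.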